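This account rests on a few compounds, and the source may have more. Where it says the series, first, only, none or still open, it means among the compounds named here.

Measured in a functional assay on A549 cells (Homo sapiens) for antiproliferative activity, read by MTT assay, with a stated time of 72 h; a lower number here means a stronger inhibitor, a higher number a weaker inhibitor:
- Compound 1 `O=C(CCC1CCCCC1)N1CCN(c2ncnc3c2nnn3Cc2ccccc2)CC1`: > 50000 nM (a limit)
- Compound 2 `O=C(NCC(=O)N1CCCC(Cc2nc(C3CC3)no2)C1)c1ccccc1`: > 50000 nM (a limit)
- Compound 3 `O=C(c1ccco1)N1CCN(Cc2cc(=O)c(OCc3ccccc3F)co2)CC1`: 7800 nM

Going by the values given here, compound 3 holds the only actual number in the set. Compounds 1 and 2 stand at the limit of > 50000 nM in this assay, at which 2 of the 3 values shown sit.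

Compound 4 `O=C(c1ccco1)N1CCN(Cc2cc(=O)c(OCc3c(F)cccc3Cl)co2)CC1` carries chloro in place of hydrogen on an aromatic carbon, which turns the 2-fluorobenzyl group into 2-chloro-6-fluorobenzyl. Among the compounds with values here, no measured step in this assay shows what this chloro in place of hydrogen does, so the expectation rests on compound 3 at 7800 nM. No change beyond the scatter is expected, and the estimated step is a 1.3-fold lower number from compound 3 to compound 4 (0.11 log units; within the scatter). For compound 4 the expected value is 6000 nM, with an estimated range from 2000 nM to 18000 nM.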

Compound 4, half-maximal inhibitory concentration: > 50000 nM
Compound 4: no number, only a limit; the forecaster's own chance of this, stated with the estimate: 8%; middle value at least 8.3-fold (0.92 log units) from the limit.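

In this assay, chloro in place of hydrogen on the 2-fluorobenzyl group gives an at least 6.4-fold higher number from compound 3 to compound 4 (0.80 log units; beyond the scatter), so this aromatic carbon is not indifferent to substitution. On these data alone, compound 4 reads > 50000 nM, which is a limit and not a number, so the full size of the step stays unknown. Compound 4 thereby joins the upper end of the set: the limit of > 50000 nM in this assay, at which 3 of the 4 values shown sit.

As far as these compounds go, whether a methyl or a methoxy group on the same carbon behaves like hydrogen or like chloro remains open. Also open, from the compounds shown here alone, is whether chloro gives the same step on a benzyl group without the fluoro group.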